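Removing the methyl from the aryl group of compound 3

The source may report more compounds than this note shows. Statements on the series, on what has been measured and on what is new or still open speak of the compounds shown alone.

Three compounds share one core. Compound 1 `CCCn1c(=O)[nH]c2nc(-c3ccc(S(=O)(=O)N4CCN(c5ccc(Cl)cc5F)CC4)cc3)[nH]c2c1=O` was tested in an assay on CHO cells for displacement of a labelled ligand from adenosine receptor A1 (Homo sapiens), read by scintillation counting, with a stated time of 90 min, in the presence of a further agent that is not named here (on this read-out higher numbers stand for weaker inhibition and lower numbers for stronger inhibition), where compound 1 gives > 1000 nM, a limit of the assay. Compound 2 `CCCn1c(=O)[nH]c2nc(-c3ccc(S(=O)(=O)N4CCN(C)CC4)cc3)[nH]c2c1=O` gives 334 nM in this assay. Compound 3 `CCCn1c(=O)[nH]c2nc(-c3ccc(S(=O)(=O)N4CCN(c5ccc(C)cc5)CC4)cc3)[nH]c2c1=O` likewise gives only a limit in this assay, > 1000 nM. Compound 3 thus stands at the limit of > 1000 nM in this assay, at which 2 of the 3 values shown sit. The step of an at least 2.9-fold higher number from compound 2 to compound 3 (0.47 log units; beyond the scatter) lies beyond the scatter, while a step that the two limits leave unreadable from compound 1 to compound 3 cannot be read. Compound 4 `CCCn1c(=O)[nH]c2nc(-c3ccc(S(=O)(=O)N4CCN(c5ccccc5)CC4)cc3)[nH]c2c1=O` differs from compound 3 by hydrogen in place of methyl on an aromatic carbon. Both measured steps concern the group on the ring amine nitrogen; the present change is smaller than either. Since compound 3 shows no number beyond its limit, the step to compound 4 is expected to be small, a step that the limit leaves unreadable from compound 3 to compound 4. Compound 4 is therefore expected to give 1500 nM, between 500 nM and 5000 nM, most probably again a limit.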

Compound 4, inhibition constant: 364 nM
The estimate for compound 4 lay 4.1-fold (0.61 log units) above the measured number; the measured number lies below the stated range.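

Taking away the methyl para to a large group is enough to change the reading in this assay, with an at least 2.7-fold lower number from compound 3 to compound 4 (0.43 log units; beyond the scatter), so the unsubstituted phenyl does not share the penalty seen with compound 3. Compound 4 also shows that an aryl group on the ring amine nitrogen need not cost anything against methyl, with a 1.1-fold higher number from compound 2 to compound 4 (0.04 log units; within the scatter), and the other substituted aryl group behaves likewise, with an at least 2.7-fold lower number from compound 1 to compound 4 (0.43 log units; beyond the scatter). Both substituted phenyl compounds, compound 1 and compound 3, give only a limit: the limit of > 1000 nM in this assay, at which 2 of the 4 values shown sit.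

Which of the chloro and fluoro groups of compound 1 matters stays open. So does whether a hydroxyl, an amine or a smaller halogen such as fluoro alone on that aromatic carbon would read like hydrogen or like methyl.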